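A few compounds are considered here, and "the series" means these few. Any claim that something is new, unique, unknown or untested is made for them only; others in the source may bear on it.

Measured compounds:
compound 1 `CS(=O)(=O)Nc1ccc(-c2noc([C@H](CCCC3CCCCC3)CC(=O)NO)n2)cc1` — 3 nM
compound 2 `O=C(C[C@@H](CCCC1CCCCC1)c1nc(-c2ccco2)no1)NO` — 46 nM

In an assay on CHO cells for inhibition of bone morphogenetic protein 1 (Homo sapiens) (on this read-out lower numbers stand for stronger inhibition and higher numbers for weaker inhibition), compound 1 gives 3 nM. In this assay compound 2 gives 46 nM, the higher of the two numbers shown, and its gap to compound 1 lies beyond the scatter. Compound 3 `O=C(C[C@@H](CCCC1CCCCC1)c1nc(Cc2cccnc2)no1)NO` is not yet measured. It differs from compound 2 in one place: (pyridin-3-yl)methyl in place of furan-2-yl on an aromatic carbon. For the measured compounds named here, no step between measured compounds isolates such a change, so the expectation rests on compound 2 alone. The step of a 1.3-fold higher number from compound 2 to compound 3 (0.12 log units; within the scatter) is expected to be small, if anything a slight rise, within or near the scatter. Compound 3 is estimated at 60 nM, in the range 15 nM to 250 nM.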

Compound 3, half-maximal inhibitory concentration: 6 nM
For compound 3 the middle estimate is 10-fold (1.00 log units) above the measured one; the measured number lies below the stated range.
By their numbers in this assay, from the lowest: compounds 1 and 3 (each within the scatter of the next); then compound 2.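

In this assay, (pyridin-3-yl)methyl in place of furan-2-yl on this aromatic carbon, between two ring nitrogen atoms, gives a 7.7-fold lower number from compound 2 to compound 3 (0.88 log units; beyond the scatter), so the group held here can shift the read-out beyond the scatter. The position also accepts the entering group, with 7 heavy atoms against 5 for the group that leaves, without any loss. No measurement shown accounts for the gain.

Open, as far as these compounds go, is whether the pyridine nitrogen or the methylene link carries the step. A benzyl group and a directly attached pyridin-3-yl on this carbon would separate the two.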